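The source may hold more compounds than are shown below. What is called first, only, known or untested is meant among the compounds shown, and "the series" means these compounds.

In a functional assay on BGC-823 cells (Homo sapiens) for antiproliferative activity, read by MTT assay, with a stated time of 24 h (on this read-out lower numbers stand for stronger inhibition and higher numbers for weaker inhibition), three compounds on one shared core have been measured. Compound 1 `Sc1nnc(-c2ccc3c(c2)OCCO3)n1-c1ccccc1` gives 47000 nM, compound 2 `O=[N+]([O-])c1cccc(CSc2nnc(-c3ccc4c(c3)OCCO4)n2-c2ccccc2)c1` gives 30100 nM, and compound 3 `O=[N+]([O-])c1ccc(CSc2nnc(-c3ccc4c(c3)OCCO4)n2-c2ccccc2)cc1` gives 48600 nM. Compound 3 therefore stands within the scatter of both of the others, and the three values show no order among themselves.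

Compound 4 `Clc1ccccc1CSc1nnc(-c2ccc3c(c2)OCCO3)n1-c1ccccc1` differs from compound 3 on a saturated chain carbon bound to a sulfur, with 2-chlorophenyl in place of 4-nitrophenyl on a saturated chain carbon bound to a sulfur.

Going by the values given here, three measured steps bear on this place: a 1.6-fold lower number from compound 1 to compound 2 (0.19 log units; within the scatter), a 1.0-fold higher number from compound 1 to compound 3 (0.01 log units; within the scatter) and a 1.6-fold higher number from compound 2 to compound 3 (0.21 log units; within the scatter). Among the compounds with values here, all three are small and lie within the scatter, although none of them involves a 2-chlorophenyl group, so the data offer no direct precedent for it. No step beyond the scatter is therefore expected in this assay, and the estimate is a 1.3-fold lower number from compound 3 to compound 4 (0.11 log units; within the scatter). Compound 4 is expected at about 38000 nM, with an estimated range of 16000 nM to 85000 nM.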

Compound 4, half-maximal inhibitory concentration: 17400 nM
Beside the measured number, compound 4's estimate is 2.2-fold (0.34 log units) above it; measured number inside the range.
By their numbers in this assay, from the lowest: compounds 4, 2, 1 and 3 (each within the scatter of the next, the first and the last beyond it).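

In this assay, going by these compounds alone, the 2-chlorobenzyl group on the sulfur gives the first steps at this place that pass beyond the scatter: a 2.8-fold lower number from compound 3 to compound 4 (0.45 log units; beyond the scatter) and, from the unsubstituted thiol, a 2.7-fold lower number from compound 1 to compound 4 (0.43 log units; beyond the scatter) on the same read-out. The earlier compounds had shown only that a nitrobenzyl group on the sulfur left the number within the scatter of the thiol, so this position is now seen to respond to the group it carries. The response is modest and does not separate compound 4 from every nitro compound, as a 1.7-fold lower number from compound 2 to compound 4 (0.24 log units; within the scatter) stays within the scatter.

On these data alone, what a plain benzyl group, a methoxybenzyl group or a longer chain on the sulfur would give remains open, as does whether the chlorine itself matters. Nothing shown here accounts for the step.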